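This account rests on a few compounds, and the source may have more. Where it says the series, first, only, none or still open, it means among the compounds named here.

In a functional assay on DU-145 cells (Homo sapiens) for inhibition, read by trypan blue exclusion, with a stated time of 72 h (on this read-out higher numbers stand for weaker inhibition and lower numbers for stronger inhibition), two compounds have been measured:
compound 1 `Cn1c(=O)c(C(=O)Nc2ccc(F)cc2F)cc2cnc(Nc3ccc4[nH]ccc4c3)nc21` gives 5000 nM
compound 2 `Cn1c(=O)c(S(=O)(=O)Cc2ccc(F)cc2)cc2cnc(Nc3ccc4[nH]ccc4c3)nc21` gives 30000 nM

Of these two, compound 2 stands higher at 30000 nM, making it the weaker inhibitor, and the gap to compound 1 lies beyond the scatter. Compound 3 `Cn1c(=O)c(C(=O)Nc2ccc(F)cc2)cc2cnc(Nc3ccc4[nH]ccc4c3)nc21` has yet to be measured in this assay. It differs from compound 2 as follows: (4-fluorophenyl)carbamoyl in place of (4-fluorobenzyl)sulfonyl on an aromatic carbon. In words, (4-fluorophenyl)carbamoyl stands in place of (4-fluorobenzyl)sulfonyl on an aromatic carbon.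

Going by the values given here, only one measured step bears on this change: a 6.0-fold higher number from compound 1 to compound 2 (0.78 log units; beyond the scatter). That modest step took (4-fluorobenzyl)sulfonyl in place of (2,4-difluorophenyl)carbamoyl at the same place, so it runs the opposite way. Among the compounds with values here, compound 1 carries (2,4-difluorophenyl)carbamoyl where compound 3 carries (4-fluorophenyl)carbamoyl, and no measured step shows what that difference does. A step of similar modest size towards a lower number is therefore expected, which widens the range. The expected change is a 5.5-fold lower number from compound 2 to compound 3 (0.74 log units; beyond the scatter). The estimate for compound 3 is 5500 nM, with an expected range of 1800 nM to 16000 nM.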

Compound 3, half-maximal inhibitory concentration: 5000 nM
Estimate against measurement, compound 3: 1.1-fold (0.04 log units) above; low and high end bracket the measured number.
By their numbers in this assay, from the lowest: compounds 1 and 3 (each within the scatter of the next); then compound 2.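

In this assay, the step of a 6.0-fold lower number from compound 2 to compound 3 (0.78 log units; beyond the scatter) isolates the exchange of (4-fluorobenzyl)sulfonyl for (4-fluorophenyl)carbamoyl at this aromatic carbon, with the same fluorine count on the entering and leaving groups. The earlier comparison of compound 1 with compound 2 also involved a second fluoro on the carbamoyl phenyl ring, but no change at the digits printed from compound 1 to compound 3 (within the scatter) for hydrogen in place of that fluoro, so among these three compounds the gap does not depend on it. Both carbamoyl compounds thus stand apart from the sulfonyl compound in this assay, but no independent data explain why the two kinds of group differ here.

The exchange alters both the linking group and the benzyl or phenyl attachment at once, so these compounds cannot say which of the two accounts for the step, something that (4-fluorophenyl)sulfonyl or (4-fluorobenzyl)carbamoyl would separate. Nor do they show how this position responds to a group without the fluorophenyl ring, such as a carboxylic acid or a simple amine.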